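Methoxy for cyclobutylamino on the shared core

A few compounds are considered here, and "the series" means these few. Any claim that something is new, unique, unknown or untested is made for them only; others in the source may bear on it.

Compound 1 `CCCc1cc(NC2CCC2)c2cc(NC(=O)/C=C/c3ccc(C(F)(F)F)cc3)ccc2n1` gives 18 nM in an assay on isolated protein for displacement of a labelled ligand from melanin-concentrating hormone receptor 1 (Homo sapiens); on this read-out lower numbers stand for stronger inhibition and higher numbers for weaker inhibition. Among the three compounds measured so far it stands second highest: compound 3 `CCc1cc(N)c2cc(NC(=O)/C=C/c3ccc(C(F)(F)F)cc3)ccc2n1` returns 1.2 nM in this assay, a lower number beyond the scatter, while compound 2 `CCCc1cc(N)c2cc(NC(=O)/C=C/c3cccc(Cl)c3)ccc2n1` returns 1100 nM in this assay, a higher number beyond the scatter. For the measured compounds named here, compound 2 and compound 3 each differ from compound 1 in more than one place, so no single step between measured compounds is available to read across.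

Compound 4 `CCCc1cc(OC)c2cc(NC(=O)/C=C/c3ccc(C(F)(F)F)cc3)ccc2n1` differs from compound 1 in one place only: methoxy in place of cyclobutylamino on an aromatic carbon. No measured pair shows what the removal of the hydrogen-bond donor at this position does, so the direction of the step rests on judgement rather than on a shown step. Compound 4 is expected to give a somewhat higher number than compound 1, with a step of a 2.8-fold higher number from compound 1 to compound 4 (0.44 log units; beyond the scatter) that reaches only modestly beyond the scatter. For compound 4 the estimate in this assay is 50 nM, with a range from 8 nM to 300 nM.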

Compound 4, half-maximal inhibitory concentration: 26 nM
For compound 4 the middle estimate is 1.9-fold (0.28 log units) above the measured one; the range from low to high includes it.
By their numbers in this assay, from the lowest: compound 3; then compounds 1 and 4 (each within the scatter of the next); then compound 2.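

In this assay methoxy in place of cyclobutylamino on the shared core gives a 1.4-fold higher number from compound 1 to compound 4 (0.16 log units; within the scatter) and so the two groups read alike at this position, opposite the ring nitrogen. For this pair, neither the four-membered ring nor the hydrogen-bond donor of cyclobutylamino is required to hold the number at the level of compound 1. No measurement at hand bears on why the two groups read alike.

Going by these compounds, whether a hydroxyl, a dimethylamino or a longer alkoxy chain such as butoxy would also read alike here remains open. The free amino group of compound 3 comes with an ethyl group in place of propyl, so whether this tolerance extends to it cannot be read from the compounds shown.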